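From Bromo to an Ester Chain on the Shared Core

This account rests on a few compounds, and the source may have more. Where it says the series, first, only, none or still open, it means among the compounds named here.

Of the compounds shown here, two on the shared core have been measured so far. Compound 1 `COCc1c(C)nc2c(OCc3ccccc3)cccn12` in a functional assay on the whole organism (stomach) for inhibition, with Canis familiaris (Canis lupus familiaris) as the target, at a dose of 5 mg/kg by the intravenous route (a lower number here means a weaker effect, a higher number a stronger effect of the compound at the dose given), gives 29%. Among the compounds with values here, compound 2 `Cc1nc2c(OCc3ccccc3)cccn2c1Br` in this assay gives 63%, the highest of the two numbers; its only neighbour is compound 1, and the step of a number 34 percentage points higher from compound 1 to compound 2 (beyond the scatter) lies beyond the scatter. Compound 3 `COC(=O)Cc1c(C)nc2c(OCc3ccccc3)cccn12` has not yet been measured in this assay. It differs from compound 2 in one place: (methoxycarbonyl)methyl in place of bromo on an aromatic carbon. Within the data shown here, the only measured step that bears on this change is a number 34 percentage points higher from compound 1 to compound 2 (beyond the scatter), where bromo replaced methoxymethyl at the same place on the five-membered aromatic ring. Compound 3 carries (methoxycarbonyl)methyl there, a chain closer in kind to the methoxymethyl of compound 1 than to the bromo of compound 2, so a drop of roughly the size of that step is expected, back toward the number of compound 1. For compound 3 in this assay the value is therefore estimated at 35%, with a range from 15% to 55%. This estimate means an expected step of a number 28 percentage points lower from compound 2 to compound 3 (beyond the scatter).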

Compound 3, a percentage reported as inhibition, in the whole organism at one dose (the size of the read-out at that dose, not a potency): 16%
Beside the measured number, compound 3's estimate is 19 percentage points above it, and the stated range covers the measured number.
By their numbers in this assay, from the lowest: compound 3; then compound 1; then compound 2.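

In this assay, the (methoxycarbonyl)methyl chain on this aromatic carbon of the five-membered ring gives a number 47 percentage points lower from compound 2 to compound 3 (beyond the scatter), which leaves compound 3 the weakest of the three and compound 2, with its single bromine, the strongest. The earlier compounds shown here showed only that bromo stood above methoxymethyl; the new result shows that a second chain at this place also stands well below bromo, so that the one halogen and both chains fall on opposite sides of a wide gap. The chains are not equivalent either: methoxycarbonyl in place of methoxy on the saturated chain carbon gives a number 13 percentage points lower from compound 1 to compound 3 (beyond the scatter), a modest step but one beyond the scatter. The data offer no measurement that would explain these differences.

The compounds shown leave open whether the high number belongs to bromine in particular or would also appear with chlorine or iodine on this carbon. They also leave open how a free carboxylic acid or an amine at the end of the chain would compare with the methyl ester of compound 3.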